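This account rests on a few compounds, and the source may have more. Where it says the series, first, only, none or still open, it means among the compounds named here.

In a functional assay on PC-3 cells (Homo sapiens) for inhibition, read by sulforhodamine B assay, with a stated time of 72 h (on this read-out lower numbers stand for stronger inhibition and higher numbers for weaker inhibition), compound 1 `CC(C)(C)NC(=O)c1c(N)sc(-c2ccc(Cl)cc2)c1-c1ccc(Cl)cc1`, which carries tert-butyl on an amide-type nitrogen, gives 15100 nM. Within the data shown here, compound 2 `Nc1sc(-c2ccc(Cl)cc2)c(-c2ccc(Cl)cc2)c1C(=O)NCc1ccccc1`, with benzyl at that place, gives 31800 nM, the higher of the two numbers measured so far and so the weaker inhibition in this assay. The next compound, compound 3 `Nc1sc(-c2ccc(Cl)cc2)c(-c2ccc(Cl)cc2)c1C(=O)NC1CCCC1`, keeps the same core and changes only this substituent: cyclopentyl in place of benzyl on an amide-type nitrogen. In words, cyclopentyl takes the place of benzyl on an amide-type nitrogen. Among the measured compounds shown here, only one measured step bears on this change, a 2.1-fold higher number from compound 1 to compound 2 (0.32 log units; beyond the scatter), a modest move that put benzyl in place of tert-butyl. Compound 3 loses the benzyl group and, like compound 1, has no six-membered aromatic ring at this place, so a small move toward the value of compound 1 is expected, though no cyclopentyl amide has yet been measured. The expected change is a 1.7-fold lower number from compound 2 to compound 3 (0.22 log units; within the scatter), and it may not clear the usual scatter. Compound 3 is estimated at 19000 nM, with an expected range of 9000 nM to 38000 nM.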

Compound 3, half-maximal inhibitory concentration: 21200 nM
The estimate for compound 3 lay 1.1-fold (0.05 log units) below the measured number; measured number inside the range.
By their numbers in this assay, from the lowest: compounds 1, 3 and 2 (each within the scatter of the next, the first and the last beyond it).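

In this assay, the step to the cyclopentyl amide is a 1.5-fold lower number from compound 2 to compound 3 (0.18 log units; within the scatter), so removing the benzyl group with its six-membered aromatic ring and placing a five-membered non-aromatic carbon ring on the amide-type nitrogen gives no change that can be told apart from scatter. The comparison with the tert-butyl amide, a 1.4-fold higher number from compound 1 to compound 3 (0.15 log units; within the scatter), is also within the scatter, so compound 3 cannot be separated from either neighbour, even though compound 1 and compound 2 lie beyond the scatter of each other. No measurement is available that would explain these small differences or the position of compound 3 among the three amides.

All three compounds carry a substituent made only of carbon at this place, so they leave open how the read-out responds to an amine, a carboxylic acid or a hydroxyl group there, or to a longer chain such as n-hexyl. They also leave open whether the small spread seen here would hold if the shared core were changed elsewhere.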